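The source may report more compounds than this note shows. Statements on the series, on what has been measured and on what is new or still open speak of the compounds shown alone.

In a functional assay on MDA-MB-231 cells (Homo sapiens) for inhibition, read by CCK-8 assay, with a stated time of 72 h, tested at 20 uM (a higher number here means more inhibition of growth at the concentration tested, a lower number less inhibition of growth), compound 2 `Cc1ccc2c(c1)/C(=C\C(=O)OC(C)(C)C)C(=O)N2` gives 87.8%. On the numbers alone compound 2 stands at the top of the two recorded, yet compound 1 `CN1C(=O)/C(=C/C(=O)OC(C)(C)C)c2ccccc21` gives 86.6% in this assay, and that gap lies within the scatter, so the two cannot be told apart. Compound 3 `CC(C)(C)OC(=O)/C=C1/C(=O)Nc2ccc(Cl)cc21` differs from compound 2 by chloro in place of methyl on an aromatic carbon. Within the data shown here, no measured pair shows this change, so its effect is unknown. Both measured compounds sit close together. The step from compound 2 to compound 3 is expected to be a number 2.8 percentage points lower from compound 2 to compound 3 (within the scatter), nothing beyond the scatter. Compound 3 is estimated at 85%, within 70% to 95%.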

Compound 3, percent growth inhibition at one concentration: 87.6%
Compound 3: middle estimate off by 2.6 percentage points, on the low side; the measured number falls inside the stated range.
By their numbers in this assay, from the lowest: compounds 1, 3 and 2 (each within the scatter of the next).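

In this assay chloro in place of methyl on this aromatic carbon gives a number 0.2 percentage points lower from compound 2 to compound 3 (within the scatter) and so, at this position, the two groups cannot be told apart. Among these compounds, this is the first measured pair to show this change, and it gives no sign that the choice between these two small groups matters here. Nothing available explains this result.

From the compounds shown here alone, whether another group at this position, such as an amine, a carboxylic acid or a longer chain, would give a clearly different number stays open. Also open, going by these compounds, is whether the same change would give a similar result on the core of compound 1 .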